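Methoxy to Cyano on the Aniline of Compound 1

The compounds below may be only part of what the source reports. "The series", "measured", "known", "first", "only" and "open" are said of these compounds alone.

Compound 1 `COc1cccc(Nc2nc(Oc3cccc(NC(=O)C=C(C)C)c3)c3sccc3n2)c1` carries the higher of the two numbers measured in a functional assay on A-431 cells (Homo sapiens) for inhibition, read by MTT assay, with a stated time of 72 h; a higher number here means a weaker inhibitor, a lower number a stronger inhibitor: compound 1 gives 25800 nM. Among the measured compounds shown here, its only measured neighbour is compound 2 `CCC/C=C/C(=O)Nc1cccc(Oc2nc(Nc3cccc(OC)c3)nc3ccsc23)c1`, which in this assay gives 8090 nM; the step of a 3.2-fold lower number from compound 1 to compound 2 (0.50 log units; beyond the scatter) concerns the group on the carbonyl carbon, pent-1-en-1-yl in place of 2-methylprop-1-en-1-yl, and leaves everything else untouched. Compound 3 `CC(C)=CC(=O)Nc1cccc(Oc2nc(Nc3cccc(C#N)c3)nc3ccsc23)c1` differs from compound 1 in another part of the molecule: cyano in place of methoxy on an aromatic carbon. For the measured compounds named here, no measured step touches this position, so the single step available, on the carbonyl side, offers no direct guidance; it shows only that one small exchange on this shared core can shift the number by a modest amount. With nothing bearing on the (3-methoxyphenyl)amino to (3-cyanophenyl)amino exchange, the expectation is for a step of at most modest size and of uncertain direction, a 1.3-fold lower number from compound 1 to compound 3 (0.11 log units; within the scatter). Compound 3 is accordingly estimated at 20000 nM, with a range from 6000 nM to 60000 nM.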

Compound 3, half-maximal inhibitory concentration: 28300 nM
Beside the measured number, compound 3's estimate is 1.4-fold (0.15 log units) below it, and the stated range covers the measured number.
By their numbers in this assay, from the lowest: compound 2; then compounds 1 and 3 (each within the scatter of the next).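

In this assay, among the compounds shown here, the exchange of methoxy for cyano on this aromatic carbon gives a 1.1-fold higher number from compound 1 to compound 3 (0.04 log units; within the scatter), the first reading at this position, and it shows that for this pair the two groups cannot be told apart in this assay. For the compounds shown here, the earlier compounds showed only the carbonyl side, where the exchange gave a 3.2-fold lower number from compound 1 to compound 2 (0.50 log units; beyond the scatter), beyond the scatter; on the core of compound 1, the one exchange read on the aniline side, by contrast, stays within the scatter, although the group that enters carries a triple bond and the group that leaves carries an oxygen. No evidence is available that bears on this result or accounts for it.

The compounds shown leave open whether a group of another kind on this aromatic carbon, such as an amine, a carboxylic acid or a longer alkoxy chain, would move the number beyond the scatter. They also leave open whether cyano in place of methoxy would read the same way on compound 2, with pent-1-en-1-yl on the carbonyl carbon, since this exchange has been read on one background only.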